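The source may report more compounds than this note shows. Statements on the series, on what has been measured and on what is new or still open speak of the compounds shown alone.

In a functional assay on HCC827 cells (Homo sapiens) for antiproliferative activity, read by sulforhodamine B assay, with a stated time of 72 h (on this read-out lower numbers stand for stronger inhibition and higher numbers for weaker inhibition), compound 1 `C#CCNCCN(C)CCNc1ccnc2cc(Cl)ccc12` gives 105000 nM. For the measured compounds named here, compound 2 `CN(CCNCc1cn(Cc2ccccc2)nn1)CCNc1ccnc2cc(Cl)ccc12` gives 16000 nM in this assay, the lower of the two numbers so far, with compound 1 sitting at a higher number and the gap between them beyond the usual scatter. Compound 3 `CN(CCNCc1cn(-c2ccnc3cc(Cl)ccc23)nn1)CCNc1ccnc2cc(Cl)ccc12` is not yet measured. It differs from compound 2 by 7-chloroquinolin-4-yl in place of benzyl on an aromatic nitrogen, so the 7-chloroquinolin-4-yl unit now occurs twice in the molecule. The step expected a 2.7-fold lower number from compound 2 to compound 3 (0.43 log units; beyond the scatter) is a modest lowering, probably just beyond the scatter. Compound 3 is estimated at 6000 nM, within a range of 2000 nM to 18000 nM.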

Compound 3, half-maximal inhibitory concentration: 18000 nM
Beside the measured number, compound 3's estimate is 3.0-fold (0.48 log units) below it; the range from low to high includes it.
By their numbers in this assay, from the lowest: compounds 2 and 3 (each within the scatter of the next); then compound 1.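

In this assay, this aromatic nitrogen of the five-membered ring accepts a larger group with no readable shift: 7-chloroquinolin-4-yl in place of benzyl gives a 1.1-fold higher number from compound 2 to compound 3 (0.05 log units; within the scatter). At this position, a second 7-chloroquinolin-4-yl unit, with its extra ring and hydrogen-bond acceptor, is therefore not separable from benzyl. No supporting data bear on why the two groups read alike. Still open, going by these compounds, is how an amine or a carboxylic acid on the benzyl ring would read. On these data alone, a longer chain between this nitrogen and the benzyl ring also remains open.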